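Adding one carbon to the long chain

This account rests on a few compounds, and the source may have more. Where it says the series, first, only, none or still open, it means among the compounds named here.

Measured so far:
compound 1 `CCCCCC(CCO)n1cnc2c(Cl)ncnc21`: > 50000 nM (a limit)
compound 2 `CCCCCCCCCCCC(CCO)n1cnc2c(Cl)ncnc21`: 7590 nM
Not yet measured:
compound 3 `CCCCCCCCCCCCC(CCO)n1cnc2c(Cl)ncnc21`

Going by the values given here, in a functional assay on HCT-116 cells (Homo sapiens) for antiproliferative activity, read by MTT assay, with a stated time of 48 h (a lower number here means a stronger inhibitor, a higher number a weaker inhibitor), compound 2 gives 7590 nM, the only actual number so far. Compound 3 differs from it by methyl in place of hydrogen on a saturated chain carbon, ten or more bonds along the chain from an aromatic nitrogen. Among the compounds with values here, one measured step bears on this: an at least 6.5-fold lower number from compound 1 to compound 2 (0.81 log units; beyond the scatter). That was a much larger change to the chain than the one now made. A small further move towards lower numbers is possible, but no step beyond the scatter is expected. The expected step is a 1.2-fold lower number from compound 2 to compound 3 (0.07 log units; within the scatter). Compound 3 is estimated at 6500 nM, with an expected range of 3000 nM to 14000 nM.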

Compound 3, half-maximal inhibitory concentration: > 50000 nM
Compound 3 ended at the assay's limit (the forecaster's own chance of this, stated with the estimate: 8%); at least 7.6-fold (0.88 log units) between middle value and limit.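

Methyl in place of hydrogen on a saturated chain carbon is not a neutral change in this series: it gives an at least 6.5-fold higher number from compound 2 to compound 3 (0.81 log units; beyond the scatter). Lengthening the chain therefore does not lower the number steadily, and compound 2 alone gives an actual number. Compound 3 returns to the same limit as compound 1: the limit of > 50000 nM in this assay, at which 2 of the 3 values shown sit.

The step from compound 1 to compound 3 cannot be read, since both values are limits. Open, as far as these compounds go, is whether a longer chain, or an amine on the chain, gives an actual number again.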